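Methoxy for hydrogen: from compound 1 to compound 3

The source may hold more compounds than are shown below. What is called first, only, known or untested is meant among the compounds shown, and "the series" means these compounds.

Compound 1 `N#C/C(=C\c1cn(Cc2ccc(Cl)cc2)c2ccccc12)C(=O)c1c[nH]c2ccccc12` is measured in a functional assay on MIA PaCa-2 cells (Homo sapiens) for cytotoxicity, read by WST assay, with a stated time of 48 h; a higher number here means a weaker inhibitor, a lower number a stronger inhibitor. In this assay compound 1 reaches only a limit of the assay, > 50000 nM. Compound 2 `COc1ccc2[nH]cc(/C=C(\C#N)C(=O)c3c[nH]c4ccc(OC)cc34)c2c1` likewise gives a limit in this assay, > 50000 nM. Compound 1 therefore stands at the limit with compound 2, as shown by the limit of > 50000 nM in this assay, at which 2 of the 2 values shown sit. Compound 3 `COc1ccc2c(C(=O)/C(C#N)=C/c3cn(Cc4ccc(Cl)cc4)c4ccccc34)c[nH]c2c1` differs from compound 1 by methoxy in place of hydrogen on an aromatic carbon, the 1H-indol-3-yl becoming 6-methoxy-1H-indol-3-yl. Going by the values given here, no step between measured compounds is available, so the expected change from compound 1 to compound 3 is none beyond the scatter, a step that the limit leaves unreadable from compound 1 to compound 3. Compound 3 is expected to give 60000 nM, from 25000 nM to 150000 nM.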

Compound 3, half-maximal inhibitory concentration: 40400 nM
Estimate against measurement, compound 3: 1.5-fold (0.17 log units) above; measured number inside the range.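

Methoxy on this aromatic carbon gives compound 3 a readable number in this assay, where the earlier values are limits, yet the step reads only as an at least 1.2-fold lower number from compound 1 to compound 3 (0.09 log units; that floor lies within the scatter). From the compounds shown here alone, this 6-methoxy-1H-indol-3-yl change therefore shows no effect beyond the scatter, and its true size remains unknown. The other values still stand at a limit: the limit of > 50000 nM in this assay, at which 2 of the 3 values shown sit.

Open, going by these compounds, is whether an amine or a hydroxyl on the same aromatic carbon would give a step beyond the scatter from compound 1. On these data alone, a carboxylic acid there is equally open.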